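Sulfone series: from compound 3 to compound 4

The compounds below may be only part of what the source reports. "The series", "measured", "known", "first", "only" and "open" are said of these compounds alone.

Three compounds have numbers in a functional assay on K562 cells (Homo sapiens) for cytotoxicity, read by trypan blue exclusion, with a stated time of 96 h; a lower number here means a stronger inhibitor, a higher number a weaker inhibitor. Compound 1 `COc1ccc(CS(=O)(=O)/C=C/c2c(OC)cc(O)cc2OC)cc1N` gives 300 nM, compound 2 `COc1cc(OC)c(/C=C/S(=O)(=O)Cc2ccc(Br)c(N)c2)c(OC)c1` gives 750 nM, and compound 3 `COC(=O)C(C)(C)Nc1cc(CS(=O)(=O)/C=C/c2c(OC)cc(OC)cc2OC)ccc1OC` gives 800 nM, the highest of the three; the gap between compound 3 and compound 2 lies within the scatter, while the gap between compound 3 and compound 1 lies beyond it. Compound 4 `COc1cc(OC)c(/C=C/S(=O)(=O)Cc2ccc(OC)c(NC(C(=O)O)c3ccccc3)c2)c(OC)c1` is not yet measured. It differs from compound 3 in one place: carboxy(phenyl)methyl in place of 1-(methoxycarbonyl)-1-methylethyl on a nitrogen on an aromatic ring. For the measured compounds named here, no measured pair shows this change, so nothing fixes the size of the step. The step is expected to be small, a 1.3-fold higher number from compound 3 to compound 4 (0.10 log units; within the scatter), with no direction beyond the scatter. For compound 4 in this assay the estimate is 1000 nM, with a range from 350 nM to 3000 nM.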

Compound 4, half-maximal inhibitory concentration: 15 nM
For compound 4 the middle estimate is 67-fold (1.82 log units) above the measured one; measured number below the stated range.
By their numbers in this assay, from the lowest: compound 4; then compound 1; then compounds 2 and 3 (each within the scatter of the next).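

In this assay, carboxy(phenyl)methyl in place of 1-(methoxycarbonyl)-1-methylethyl on this nitrogen gives a 53-fold lower number from compound 3 to compound 4 (1.73 log units; beyond the scatter), a large step. For the compounds shown here, the substituent on this nitrogen can therefore move the number strongly, which the earlier compounds, with no one-place pair among them, could not show.

The change swaps the methyl ester for a carboxylic acid and the two methyl groups for a phenyl ring at once, so the compounds shown do not assign the step to either part. 1-Carboxy-1-methylethyl and (methoxycarbonyl)(phenyl)methyl on the same nitrogen would separate the two, and nothing at hand gives a cause for the step.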